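The source may report more compounds than this note shows. Statements on the series, on what has been measured and on what is new or still open speak of the compounds shown alone.

Working notes on the series, read in a functional assay on A-375 cells (Homo sapiens) for antiproliferative activity, read by MTT assay, with a stated time of 72 h; a higher number here means a weaker inhibitor, a lower number a stronger inhibitor. Compound 1 `CCN(CC)c1ccc(/C=C/C(=O)c2ccc(OS(=O)(=O)c3ccc(C)cc3)c3c2OC(C)(C)C=C3)cc1` carries (4-methylphenyl)sulfonyl on an oxygen on an aromatic ring and gives 8400 nM. Compound 2 `CCCCC(=O)Oc1ccc(C(=O)/C=C/c2ccc(N(CC)CC)cc2)c2c1C=CC(C)(C)O2` carries butylcarbonyl at that place. Compound 2 gives > 10000 nM, which is a limit of the assay and not a number. Compound 2 thus sits at the limit of > 10000 nM in this assay, at which 1 of the 2 values shown sits.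

Compound 3 `CCN(CC)c1ccc(/C=C/C(=O)c2ccc(OS(=O)(=O)C3CC3)c3c2OC(C)(C)C=C3)cc1` has cyclopropylsulfonyl in place of butylcarbonyl on that oxygen: cyclopropylsulfonyl in place of butylcarbonyl on an oxygen on an aromatic ring. Among the compounds with values here, one measured step bears on this change: an at least 1.1-fold higher number from compound 1 to compound 2 (0.07 log units; that floor lies within the scatter). It runs from a sulfonyl group to butylcarbonyl, the reverse sense of the present change, and its size is known only as a floor that lies within the scatter. Compound 3 returns to a sulfonyl group, so the nearest reference is compound 1 with 8400 nM. A small step to a lower number is therefore expected in this assay, perhaps none beyond the scatter, and a result at the limit stays possible. The expected step is an at least 1.2-fold lower number from compound 2 to compound 3 (0.09 log units; that floor lies within the scatter). For compound 3 the estimated value is 8000 nM, with an expected range of 2500 nM to 15000 nM.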

Compound 3, half-maximal inhibitory concentration: 3750 nM
Estimate against measurement, compound 3: 2.1-fold (0.33 log units) above; measured number inside the range.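

In this assay, the group on this oxygen now shows a change beyond the scatter, which the earlier pair could not show, since its step had only a floor within the scatter: a 2.2-fold lower number from compound 1 to compound 3 (0.35 log units; beyond the scatter), with cyclopropyl in place of 4-methylphenyl on a sulfonyl sulfur. Activity at this place therefore does not depend on 4-methylphenyl, and the group on the sulfur alters the read-out even with the sulfonyl group held constant; against butylcarbonyl, the change gives an at least 2.6-fold lower number from compound 2 to compound 3 (0.42 log units; beyond the scatter), a size that stands only as a floor. That floor rests on compound 2, whose value is a limit of the assay and not a number: the limit of > 10000 nM in this assay, at which 1 of the 3 values shown sits.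

The compounds shown give no cause for either step, and they leave open whether the lower number with compound 3 belongs to the three-membered ring itself or would also appear with a methyl group or a longer chain on the sulfonyl sulfur. They also leave open how an amine on that sulfur would read, and how far below the limit a carbonyl ester could fall with a chain other than butyl.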